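Ethoxy for Methoxy on a Shared Core

A few compounds are considered here, and "the series" means these few. Any claim that something is new, unique, unknown or untested is made for them only; others in the source may bear on it.

Compound 1, `Cc1cccc(-n2nncc2CN2C(=O)C3(C(C#N)=C(N)Oc4c(N)cc5nc6ccccc6nc5c43)c3ccccc32)c1`: > 50000 nM
Compound 2, `COc1ccc(-n2nncc2CN2C(=O)C3(C(C#N)=C(N)Oc4c(N)cc5nc6ccccc6nc5c43)c3ccccc32)cc1`: > 50000 nM

Of the compounds shown here, two have been measured in an ADME assay on HUVEC cells (Homo sapiens) for antiproliferative activity, read by MTT assay, with a stated time of 48 h; a higher number here means a weaker inhibitor, a lower number a stronger inhibitor. Compound 1 gave only the assay limit > 50000 nM. Compound 2 likewise gave only the limit > 50000 nM. The step that the two limits leave unreadable from compound 1 to compound 2 is therefore of unreadable size, and compound 2 stands at the limit of > 50000 nM in this assay, at which 2 of the 2 values shown sit, a limit rather than a number. Compound 3, `CCOc1ccc(-n2nncc2CN2C(=O)C3(C(C#N)=C(N)Oc4c(N)cc5nc6ccccc6nc5c43)c3ccccc32)cc1`, differs from compound 2 by methyl in place of hydrogen on a saturated chain carbon bound to an oxygen on an aromatic ring. For the measured compounds named here, the only measured step is unreadable, so it offers no direction or size for the change from methoxy to ethoxy; with both measured neighbours sitting at the limit, no step beyond the scatter can be read from these data. Compound 3 is therefore expected to sit at the same limit, estimated at 50000 nM with a range of 20000 nM to 120000 nM. The expected step of a number no higher from compound 2 to compound 3 (the limit leaves the size open) is thus none beyond the scatter.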

Compound 3, half-maximal inhibitory concentration: > 50000 nM
Compound 3: a limit, no number (the forecaster's own chance of this, stated with the estimate: 85%); the middle value lies on the limit itself.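

Compound 3 gave only a limit, > 50000 nM, so its steps from compound 1 and compound 2 cannot be read. Compound 1, compound 2 and compound 3 leave open whether changing the aryl group on the shared core alters the true values at all.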